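Chloro for fluoro on two nitro positional isomers

A few compounds are considered here, and "the series" means these few. Any claim that something is new, unique, unknown or untested is made for them only; others in the source may bear on it.

compound 1 `O=C1/C(=C/c2ccc(F)cc2)CCC/C1=C\c1cccc([N+](=O)[O-])c1`: 5050 nM
compound 2 `O=C1/C(=C/c2ccc(F)cc2)CCC/C1=C\c1ccccc1[N+](=O)[O-]`: 1510 nM
compound 3 `O=C1/C(=C/c2ccc(Cl)cc2)CCC/C1=C\c1ccccc1[N+](=O)[O-]`: 1750 nM

Of the compounds shown here, three have been measured in a functional assay on CCRF-CEM cells (Homo sapiens) for cytotoxicity, with a stated time of 72 h; on this read-out higher numbers stand for weaker inhibition and lower numbers for stronger inhibition. Compound 1 gives the highest number of the three, while compound 2 and compound 3 sit within the usual scatter of each other. Compounds 1 and 2 have the same atoms joined differently; the difference between the two cores is not broken down here. Compound 3 differs from compound 2 by chloro in place of fluoro on an aromatic carbon, and that change made a 1.2-fold higher number from compound 2 to compound 3 (0.06 log units; within the scatter).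

Compound 4 `O=C1/C(=C/c2ccc(Cl)cc2)CCC/C1=C\c1cccc([N+](=O)[O-])c1` has not yet been measured. For the measured compounds named here, it differs from compound 1 by chloro in place of fluoro on an aromatic carbon, the same change as the one from compound 2 to compound 3, made on the core of compound 1. For compound 4 the expected step is a 1.1-fold higher number from compound 1 to compound 4 (0.06 log units; within the scatter), resting on the measured 1.2-fold higher number from compound 2 to compound 3 (0.06 log units; within the scatter). Compound 4 is therefore estimated at 5800 nM, with the likely range running from 3000 nM to 11000 nM.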

Compound 4, half-maximal inhibitory concentration: 1750 nM
For compound 4 the middle estimate is 3.3-fold (0.52 log units) above the measured one; the whole stated range lies above it.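

In this assay, chloro in place of fluoro on an aromatic carbon gave a 2.9-fold lower number from compound 1 to compound 4 (0.46 log units; beyond the scatter), a step beyond the scatter on the core of compound 1. The change therefore did not carry over with the same size between these two nitro positional isomers, and a step read on one core was a poor guide to the other: the same change on two cores in this assay, a 1.2-fold higher number (0.06 log units; within the scatter) from compound 2 to compound 3 and a 2.9-fold lower number (0.46 log units; beyond the scatter) from compound 1 to compound 4, 3.3-fold (0.52 log units) apart, beyond the scatter of two such steps. This rests on just one pair of compounds per core, so it shows that the step depends on the core in these four compounds, but not why it does, nor how the change would behave on any further core.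

On these data alone, whether the difference between the two steps follows the position of the nitro group in general remains open, as only two positions appear here. Also open, as far as these compounds go, is whether bromo or methoxy in place of the chloro, or an amine in place of the nitro group, would show the same dependence on the core.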